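The source may report more compounds than this note shows. Statements on the series, on what has been measured and on what is new or still open speak of the compounds shown alone.

Working notes on the aryl sulfonate series

All members share the core of compound 1 `O=C(Oc1ccc(-c2cncn2C2CCN(C(=O)c3ccc(Cl)c(C(F)(F)F)c3)CC2)cc1)c1cccs1`, differing in the group attached through oxygen to the phenyl ring. In an assay on HEK293 cells for antagonist activity at P2X purinoceptor 7 (Homo sapiens), read by fluorescence, with a stated time of 2 h (on this read-out higher numbers stand for weaker inhibition and lower numbers for stronger inhibition), compound 1 gives only a limit, > 10000 nM, not a number. Of the three results so far, one sits at this ceiling (the limit of > 10000 nM in this assay, at which 1 of the 3 values shown sits).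

Compound 2 `O=C(c1ccc(Cl)c(C(F)(F)F)c1)N1CCC(n2cncc2-c2ccc(OS(=O)(=O)c3cccc4ccccc34)cc2)CC1`, which carries a naphthalen-1-yl group on the sulfonyl sulfur, gives 3520 nM in this assay; this is the highest of the two numeric values. Compound 3 `CCN(CC)C(=O)c1cccc(S(=O)(=O)Oc2ccc(-c3cncn3C3CCN(C(=O)c4ccc(Cl)c(C(F)(F)F)c4)CC3)cc2)c1`, with a diethylcarbamoyl-substituted phenyl on the sulfonyl sulfur, gives 202 nM, a clearly stronger result, beyond the scatter. Among the compounds with values here, no two measured compounds differ in a single place, so no single step has been isolated yet.

Compound 4 `O=C(c1ccc(Cl)c(C(F)(F)F)c1)N1CCC(n2cncc2-c2ccc(OS(=O)(=O)c3cccc4cnccc34)cc2)CC1` is the next probe of the sulfonyl substituent: isoquinolin-5-yl in place of naphthalen-1-yl on a sulfonyl sulfur. Within the data shown here, the change keeps the bicyclic aromatic shape and adds one hydrogen-bond acceptor; no measured pair tests this kind of swap. The expectation is a small step, a 1.4-fold lower number from compound 2 to compound 4 (0.15 log units; within the scatter), toward stronger inhibition but likely near the edge of the scatter. Compound 4 is therefore estimated at 2500 nM in this assay, with a plausible range from 800 nM to 8000 nM.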

Compound 4, half-maximal inhibitory concentration: 45 nM
Beside the measured number, compound 4's estimate is 56-fold (1.74 log units) above it; the measured number lies below the stated range.
By their numbers in this assay, from the lowest: compound 4; then compound 3; then compound 2. At a limit, above all of these: compound 1.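

In this assay, within the data shown here, isoquinolin-5-yl in place of naphthalen-1-yl on a sulfonyl sulfur gives a 78-fold lower number from compound 2 to compound 4 (1.89 log units; beyond the scatter), the only single-place step so far. The earlier compounds shown here differed from one another in whole groups, so they could not show that this position responds so strongly to a swap that leaves the count at 10 heavy atoms, exchanges one ring carbon for nitrogen and adds one hydrogen-bond acceptor. No measured property in hand accounts for the size of this step.

Going by these compounds, whether the step depends on the ring nitrogen alone, on where it sits, or on the presence of the second ring stays open, and quinolin-5-yl or pyridin-3-yl on the same sulfonyl sulfur would help to separate these possibilities. It is also open whether the step carries over to the carboxylic ester linkage of compound 1 or to a sulfonamide linkage in place of the sulfonate oxygen, since the pair of compounds shown holds that linkage fixed.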